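Swapping an Ether-Linked Chain for a Trifluoroethoxy Group

The source may hold more compounds than are shown below. What is called first, only, known or untested is meant among the compounds shown, and "the series" means these compounds.

In an ADME assay on Vero cells (Chlorocebus sabaeus) for cytotoxicity, read by resazurin assay, with a stated time of 3 days (a lower number here means a stronger inhibitor, a higher number a weaker inhibitor), compound 1 `CCN(CC)c1cc2[nH]c(C3CCCCC3)nc2cc1NC(=O)NCc1ccccc1` gives > 100 ug/mL, which is a limit of the assay rather than a number. Compound 2 `CN(C)c1cc2[nH]c(C3CCCCC3)nc2cc1NC(=O)OCc1ccccc1` also gives > 100 ug/mL, again a limit. Compound 3 `CCCOCC(=O)Nc1cc2nc(C3CCCCC3)[nH]c2cc1N(C)C` sits at < 50 ug/mL, once more a limit. For the measured compounds named here, every value so far is a limit (the limit of < 50 ug/mL in this assay, at which 1 of the 3 values shown sits, and (the limit of > 100 ug/mL in this assay, at which 2 of the 3 values shown sit)), so the only measured step, an at least 2.0-fold lower number from compound 2 to compound 3 (0.30 log units; that floor lies within the scatter), is merely a floor. Compound 4 `CN(C)c1cc2[nH]c(C3CCCCC3)nc2cc1NC(=O)OCC(F)(F)F` differs from compound 3 by 2,2,2-trifluoroethoxy in place of propoxymethyl on a carbonyl carbon. Compound 2 carries an oxygen-linked group on the same carbonyl carbon, as compound 4 does, and that step bears on the change here. Compound 4 is therefore expected to give 80 ug/mL, within 30 ug/mL to 150 ug/mL, an expected step of an at least 1.6-fold higher number from compound 3 to compound 4 (0.20 log units; that floor lies within the scatter).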

Compound 4, half-maximal inhibitory concentration: > 100 ug/mL
Compound 4 ended at the assay's limit; the forecaster's own chance of this, stated with the estimate: 70%; middle value at least 1.2-fold (0.09 log units) away from the limit.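

In this assay, 2,2,2-trifluoroethoxy in place of propoxymethyl on the carbonyl carbon gives an at least 2.0-fold higher number from compound 3 to compound 4 (0.30 log units; that floor lies within the scatter), so a group with no ring at this place need not bring the number down as compound 3 might have suggested. Compound 4 gives only a limit of the assay: the limit of > 100 ug/mL in this assay, at which 3 of the 4 values shown sit. The step from compound 2 to compound 4 cannot be read, as both values are limits.

Still open, going by these compounds, is how far apart these limit-bound compounds truly lie. Also open, on these data alone, is how an amine or a longer ether chain on this carbonyl carbon would read.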